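A few compounds are considered here, and "the series" means these few. Any claim that something is new, unique, unknown or untested is made for them only; others in the source may bear on it.

Measured in an assay on cell membranes for displacement of a labelled ligand from corticotropin-releasing factor receptor 1 (Rattus norvegicus); on this read-out lower numbers stand for stronger inhibition and higher numbers for weaker inhibition:
compound 1 `COc1ccc(-c2c(C)nn3c(NC4CCC4)nc(C)nc23)c(C)c1`, 24.6 nM
compound 2 `COc1ccc(-c2c(C)nn3c(N4CCCC4)nc(C)nc23)c(C)c1`, 80.7 nM
compound 3 `CCCN(CCC#N)c1nc(C)nc2c(-c3ccc(OC)cc3C)c(C)nn12`, 2.16 nM

Among these three numbers compound 1 holds the second highest. Its nearest neighbour is compound 2, reached by a 3.3-fold higher number from compound 1 to compound 2 (0.52 log units; beyond the scatter); the furthest is compound 3, reached by an 11-fold lower number from compound 1 to compound 3 (1.06 log units; beyond the scatter). Compound 4 `COc1cc(C)c(-c2c(C)nn3c(NC4CCC4)nc(C)nc23)c(OC)c1` differs from compound 1 by methoxy in place of hydrogen on an aromatic carbon. Neither measured step bears on this change: both alter the amino substituent on the shared core, while the aryl ring carries the same groups in compounds 1, 2 and 3. With no such guidance, compound 4 is expected to stay close to compound 1, with a step of a 1.0-fold higher number from compound 1 to compound 4 (0.01 log units; within the scatter) that lies within the scatter. Compound 4 is therefore estimated at 25 nM, ranging from 8 nM to 80 nM.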

Compound 4, half-maximal inhibitory concentration: 17.4 nM
Estimate against measurement, compound 4: 1.4-fold (0.16 log units) above; the range from low to high includes it.
By their numbers in this assay, from the lowest: compound 3; then compounds 4 and 1 (each within the scatter of the next); then compound 2.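

In this assay, methoxy in place of hydrogen, on the aromatic carbon ortho to a large group, gives a 1.4-fold lower number from compound 1 to compound 4 (0.15 log units; within the scatter) and is the only change shown on that ring. At this position, then, the added methoxy leaves the number within the scatter, unlike the beyond-scatter steps at the amino substituent. No measured evidence accounts for this result. Going by these compounds, whether ethoxy or chlorine at this position would also stay within the scatter remains open, as does whether methoxy would do so alongside the (2-cyanoethyl)(propyl)amino group of compound 3.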